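The source may hold more compounds than are shown below. What is called first, only, known or untested is meant among the compounds shown, and "the series" means these compounds.

In a functional assay on RAW264.7 cells (Mus musculus) for inhibition, with stated times of 2 h and 24 h (on this read-out higher numbers stand for weaker inhibition and lower numbers for stronger inhibition), the measured compounds are:
Compound 1 `COc1ccc([C@@H]2c3c(OC)cc(OC)cc3C(O)[C@H]2c2cc(OC)cc(OC)c2)cc1`: 7870 nM
Compound 2 `COc1ccc([C@@H]2c3c(OC)cc(OC)cc3C(SCc3ccccc3)[C@H]2c2cc(OC)cc(OC)c2)cc1`: > 200000 nM (a limit)
Compound 3 `COc1ccc([C@@H]2c3c(OC)cc(OC)cc3C(SCc3ccc(F)cc3)[C@H]2c2cc(OC)cc(OC)c2)cc1`: > 200000 nM (a limit)

Compound 3 has no exact number and stands at the limit of > 200000 nM in this assay, at which 2 of the 3 values shown sit. Compound 4 `COc1ccc(C(O)C2c3cc(OC)cc(OC)c3[C@@H](c3ccc(OC)cc3)[C@@H]2c2cc(OC)cc(OC)c2)cc1` carries hydroxy(4-methoxyphenyl)methyl in place of (4-fluorobenzyl)sulfanyl on a saturated ring carbon. For the measured compounds named here, two measured steps bear on this change, an at least 25-fold higher number from compound 1 to compound 2 (1.40 log units; beyond the scatter) and an at least 25-fold higher number from compound 1 to compound 3 (1.40 log units; beyond the scatter), both large and beyond the scatter. Each replaces hydroxy with a sulfanyl group, and compound 4 regains a hydroxy, though within a larger group. A sizeable move towards stronger inhibition in this assay is therefore expected, and the result may still prove to be a limit. The expected step is an at least 6.6-fold lower number from compound 3 to compound 4 (0.82 log units; beyond the scatter). For compound 4, the estimated value is 30000 nM, with an expected range of 6000 nM to 200000 nM.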

Compound 4, half-maximal inhibitory concentration: > 200000 nM
Compound 4: no number, only a limit; the forecaster's own chance of this, stated with the estimate: 30%; at least 6.6-fold (0.82 log units) between middle value and limit.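

Compound 4 gives only a limit in this assay: the limit of > 200000 nM in this assay, at which 3 of the 4 values shown sit. The loss seen with the two sulfanyl groups therefore also appears with a sulfur-free group carrying its own hydroxy, with an at least 25-fold higher number from compound 1 to compound 4 (1.40 log units; beyond the scatter), so at this position hydroxy(4-methoxyphenyl)methyl does not match the plain hydroxy. The steps from compound 2 and compound 3 to compound 4 cannot be read, as both ends of each are limits.

Going by these compounds, whether a smaller group on this saturated ring carbon, such as an amine or a methoxy, keeps a measurable reading remains open.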